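Working notes: tail changes at the ring amine nitrogen

The compounds below may be only part of what the source reports. "The series", "measured", "known", "first", "only" and "open" are said of these compounds alone.

Measured so far in an assay on HEK293 cells for displacement of a labelled ligand from 5-hydroxytryptamine receptor 4 (Homo sapiens), read by scintillation counting; a lower number here means a stronger inhibitor, a higher number a weaker inhibitor:
- compound 1, `CCCCCN1CCC(NC(=O)c2cc(Cl)c(N)cc2OC)CC1`: 100 nM
- compound 2, `COc1cc(N)c(Cl)cc1C(=O)NC1CCN(CCCCCCCCO)CC1`: 79.4 nM
- compound 3, `COc1cc(N)c(Cl)cc1C(=O)NC1CCN(CCCCCCCCS(=O)(=O)O)CC1`: 15800 nM

Compound 3 carries the highest number of the three in this assay. From compound 1 the step is a 160-fold higher number from compound 1 to compound 3 (2.20 log units; beyond the scatter), and from compound 2 it is a 200-fold higher number from compound 2 to compound 3 (2.30 log units; beyond the scatter); both are large and well beyond the scatter. Between compound 1 and compound 2 the step is a 1.3-fold lower number from compound 1 to compound 2 (0.10 log units; within the scatter), so the two chains without a sulfo group sit together.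

Compound 4, `COc1cc(N)c(Cl)cc1C(=O)NC1CCN(CCN2CCCCC2)CC1`, is next. The change from compound 3 is piperidin-1-yl in place of 6-sulfohexyl on a saturated chain carbon, two bonds along the chain from an amine nitrogen in a ring. Among the measured compounds shown here, the two large steps into compound 3 both bear on it: each time a sulfo-bearing chain was the sole change, the number rose sharply. Compound 4 removes that chain entirely, so the expectation is that this assay falls back toward the range of compound 1 and compound 2. For the measured compounds named here, nothing among the measured compounds tests a piperidin-1-yl on the chain, so the exact landing point is open.

For compound 4 the estimate is 70 nM, range 20 nM to 250 nM, which is an expected step of a 230-fold lower number from compound 3 to compound 4 (2.35 log units; beyond the scatter).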

Compound 4, inhibition constant: 251 nM
Estimate against measurement, compound 4: 3.6-fold (0.55 log units) below, outside the stated range (above it).
By their numbers in this assay, from the lowest: compounds 2 and 1 (each within the scatter of the next); then compound 4; then compound 3.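

In this assay the sulfo-bearing chain is what costs affinity at this place, and a short tail carrying piperidin-1-yl recovers most of the loss, with a 63-fold lower number from compound 3 to compound 4 (1.80 log units; beyond the scatter). The recovery is not complete: a 3.2-fold higher number from compound 2 to compound 4 (0.50 log units; beyond the scatter) and a 2.5-fold higher number from compound 1 to compound 4 (0.40 log units; beyond the scatter) are both modest but beyond the scatter, so at this place, two bonds along the chain from an amine nitrogen in a ring, piperidin-1-yl does not match the pentyl and 8-hydroxyoctyl tails and the series shows some sensitivity among tails without a sulfo group. Nothing available explains these differences in the numbers.

The compounds shown leave open whether the modest step follows from the ring, from its amine nitrogen or from the shorter overall tail, and cyclohexyl, morpholin-4-yl or dimethylamino at the same place, or a longer chain ending in piperidin-1-yl, would separate these readings. Going by these compounds, it also remains open whether the large rise seen with the sulfo group extends to a carboxylic acid or a sulfonamide at the end of the long chain.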